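Moving the chloro substituent around the aryl ring on the triazole nitrogen

This account rests on a few compounds, and the source may have more. Where it says the series, first, only, none or still open, it means among the compounds named here.

Measured compounds:
Compound 1 `Cc1cccc(-n2cc(-c3ccccc3NS(=O)(=O)c3c[nH]c(=O)[nH]c3=O)nn2)c1`: 3150 nM
Compound 2 `O=c1[nH]cc(S(=O)(=O)Nc2ccccc2-c2cn(-c3ccccc3F)nn2)c(=O)[nH]1`: 15300 nM
Compound 3 `O=c1[nH]cc(S(=O)(=O)Nc2ccccc2-c2cn(-c3cccc(Cl)c3)nn2)c(=O)[nH]1`: 2180 nM

In a functional assay on OVCAR-3 cells (Homo sapiens) for antiproliferative activity, read by MTT assay, with a stated time of 24 h (on this read-out higher numbers stand for weaker inhibition and lower numbers for stronger inhibition), compound 1 gives 3150 nM, the second highest of the three numbers; its nearest neighbour is compound 3, with a 1.4-fold lower number from compound 1 to compound 3 (0.16 log units; within the scatter), while compound 2 lies furthest away, with a 4.9-fold higher number from compound 1 to compound 2 (0.69 log units; beyond the scatter). The unmeasured compound 4 `O=c1[nH]cc(S(=O)(=O)Nc2ccccc2-c2cn(-c3ccc(Cl)cc3)nn2)c(=O)[nH]1` differs from compound 1 in one place: 4-chlorophenyl in place of 3-methylphenyl on an aromatic nitrogen. Within the data shown here, two measured steps bear on this change. The swap of chloro for methyl on the same carbon, a 1.4-fold lower number from compound 1 to compound 3 (0.16 log units; within the scatter), stayed within the scatter, so chlorine itself does not shift this assay much. The change of substitution pattern on the aryl ring, however, mattered: a 4.9-fold higher number from compound 1 to compound 2 (0.69 log units; beyond the scatter) and a 7.0-fold lower number from compound 2 to compound 3 (0.85 log units; beyond the scatter) were both beyond the scatter. Among the measured compounds shown here, no measured compound carries a group at the 4-position of this ring, so the direction of that shift is uncertain. Compound 4 is therefore expected to land near compound 1, with a 1.2-fold lower number from compound 1 to compound 4 (0.08 log units; within the scatter) expected, giving an estimate of 2600 nM with a range of 800 nM to 9000 nM.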

Compound 4, half-maximal inhibitory concentration: 1750 nM
For compound 4 the middle estimate is 1.5-fold (0.17 log units) above the measured one; the range from low to high includes it.
By their numbers in this assay, from the lowest: compounds 4, 3 and 1 (each within the scatter of the next); then compound 2.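

Replacing the 3-chlorophenyl group with 4-chlorophenyl on the aromatic nitrogen leaves the result within the scatter in this assay (a 1.2-fold lower number from compound 3 to compound 4 (0.10 log units; within the scatter)). The same holds when 4-chlorophenyl replaces the 3-methylphenyl group (a 1.8-fold lower number from compound 1 to compound 4 (0.26 log units; within the scatter)), so compound 1, compound 3 and compound 4 cannot be ranked against one another. Among these compounds, compound 2 remains the outlier, and its 2-fluorophenyl group also separates it from the new compound (an 8.7-fold lower number from compound 2 to compound 4 (0.94 log units; beyond the scatter)), the only one of these three steps beyond the scatter. No measurement at hand accounts for these results.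

The compounds shown leave open whether the higher number of compound 2 belongs to fluorine or to its place on the ring, which a 2-chlorophenyl group could help to separate. They also give no reading for an amine or a carboxylic acid on this aryl ring.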